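Spiro amine swap on the benzyl series: tolerance expectation

The source may report more compounds than this note shows. Statements on the series, on what has been measured and on what is new or still open speak of the compounds shown alone.

Working notes on the shared core, followed from compound 1 to compound 4.

Compound 1 `COc1ccc2[nH]c(C(=O)N3CC(=O)N(Cc4ccccc4)[C@@H](CN4CCC5(CC4)CC5)C3)cc2c1` was measured in an ADME assay on Vero cells (Chlorocebus sabaeus) for cytotoxicity, with a stated time of 7 days (a higher number here means that more compound is tolerated, a lower number that less compound is tolerated), and gives 17100 nM. Compound 2 `COc1ccc2[nH]c(C(=O)N3CC(=O)N(Cc4ccc[nH]4)[C@@H](Cc4ccccc4)C3)cc2c1` gives 15200 nM in this assay, and compound 3 `COc1ccc2[nH]c(C(=O)N3CC(=O)N(Cc4cccc(OC(F)F)c4)[C@@H](CN4CC5CCC4C5)C3)cc2c1` gives 26900 nM in this assay. The number for compound 1 lies between those of compound 2 and compound 3, and neither gap exceeds the usual scatter of repeat measurements, so the three compounds cannot be told apart on tolerated concentration. Going by the values given here, no step between two measured compounds that differ in a single place is available in this set.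

Compound 4 `COc1ccc2[nH]c(C(=O)N3CC(=O)N(Cc4ccccc4)[C@@H](CN4CC5(CCC5)C4)C3)cc2c1` has not yet been measured in this assay. It differs from compound 1 as follows: a group of 7 heavy atoms (6 carbon, 1 nitrogen; one four-membered non-aromatic ring of carbon only, one four-membered non-aromatic ring with 1 hetero atom) in place of a group of 8 heavy atoms (7 carbon, 1 nitrogen; one three-membered non-aromatic ring of carbon only, one six-membered non-aromatic ring with 1 hetero atom), on a saturated chain carbon bound to a saturated ring carbon. Since the three measured compounds sit within the scatter of one another despite differing at several places, there is no basis in these numbers for expecting the change to the group with one four-membered non-aromatic ring of carbon only and one four-membered non-aromatic ring with one hetero atom to move the tolerated concentration beyond the scatter. The step from compound 1 to compound 4 is therefore expected to be small, a 1.1-fold higher number from compound 1 to compound 4 (0.02 log units; within the scatter), in no particular direction. For compound 4 the estimated value in this assay is 18000 nM, with an expected range from 9000 nM to 36000 nM.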

Compound 4, half-maximal cytotoxic concentration: 52700 nM
Compound 4: middle estimate off by 2.9-fold (0.47 log units), on the low side, and the stated range ends below it.
By their numbers in this assay, from the lowest: compounds 2, 1, 3 and 4 (each within the scatter of the next, the first and the last beyond it).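

In this assay, going by these compounds alone, the change on a saturated chain carbon bound to a saturated ring carbon gives a 3.1-fold higher number from compound 1 to compound 4 (0.49 log units; beyond the scatter), the only step in the set that isolates a single place, and it shows that this place can move the tolerated concentration beyond the scatter. The step is modest, and it comes with the group with one four-membered non-aromatic ring of carbon only and one four-membered non-aromatic ring with 1 hetero atom replacing the group with one three-membered non-aromatic ring of carbon only and one six-membered non-aromatic ring with 1 hetero atom, while the counts of hydrogen-bond donors and acceptors and the net charge stay the same. No measurement at hand bears on what lies behind this step.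

A single step cannot separate the contribution of either ring from that of the change as a whole. On these data alone, how a morpholine or a dimethylamino group at this place would read in this assay, and whether the step recurs with a different group elsewhere on the shared core, remains open.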